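Nitro in Place of Fluoro on a Weakly Cytotoxic Core

The source may report more compounds than this note shows. Statements on the series, on what has been measured and on what is new or still open speak of the compounds shown alone.

Compound 1 `CCn1c(/C=C2/C(=O)Nc3ccc(F)cc32)nc2ccccc21` carries an ethyl on the aromatic nitrogen. In a functional assay on MCF7 cells (Homo sapiens) for cytotoxicity, read by MTT assay, with a stated time of 48 h (a lower number here means a stronger inhibitor, a higher number a weaker inhibitor), compound 1 gives > 50000 nM, which is a limit of the assay rather than a number (the limit of > 50000 nM in this assay, at which 1 of the 3 values shown sits). Compound 2 `CC(C)n1c(/C=C2/C(=O)Nc3ccc(F)cc32)nc2ccccc21` gives 29000 nM, and compound 3 `Cn1c(/C=C2/C(=O)Nc3ccc(F)cc32)nc2ccccc21` gives 31600 nM. The measured steps of an at least 1.7-fold lower number from compound 1 to compound 2 (0.23 log units; that floor lies within the scatter), an at least 1.5-fold lower number from compound 1 to compound 3 (0.19 log units; that floor lies within the scatter) and a 1.1-fold higher number from compound 2 to compound 3 (0.04 log units; within the scatter) each alter only the group on the aromatic nitrogen and leave the fluoro untouched. Compound 4 `CCn1c(/C=C2/C(=O)Nc3ccc([N+](=O)[O-])cc32)nc2ccccc21` differs from compound 1 by nitro in place of fluoro on an aromatic carbon. Within the data shown here, no measured step bears on this change, so the limit of compound 1 is the only anchor. The step of an at least 1.6-fold lower number from compound 1 to compound 4 (0.22 log units; that floor lies within the scatter) is expected to be modest, with no firm direction. Compound 4 is estimated at 30000 nM, between 8000 nM and 100000 nM.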

Compound 4, half-maximal inhibitory concentration: > 50000 nM
Compound 4 gave a limit, no number; the forecaster's own chance of this, stated with the estimate: 40%; at least 1.6-fold (0.22 log units) between middle value and limit.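

In this assay compound 4 gives > 50000 nM, a limit of the assay. Among these compounds, compound 1 also stands at a limit, and no step from it to compound 4 can be read. Going by these compounds, whether nitro in place of fluoro shifts the value at all stays open.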